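A Methoxy-to-Chloro Swap Repeated on a Second Core

A few compounds are considered here, and "the series" means these few. Any claim that something is new, unique, unknown or untested is made for them only; others in the source may bear on it.

Three compounds have been measured in a functional assay on MIA PaCa-2 cells (Homo sapiens) for cytotoxicity; a higher number here means a weaker inhibitor, a lower number a stronger inhibitor:

Compound 1, `COc1ccc(Cn2cc(/C=N\NC(=O)c3c[nH]c4ccccc34)c3cc(OC)ccc32)cc1`, gives 30500 nM.
Compound 2, `COc1ccc2c(c1)c(/C=N\NC(=O)c1c[nH]c3ccccc13)cn2Cc1ccc(Cl)cc1`, gives 26700 nM.
Compound 3, `COc1ccc(Cn2cc(/C=N\NC(=O)c3c[nH]c4ccc(Br)cc34)c3ccc(F)cc32)cc1`, gives 45500 nM.

Compound 1 and compound 2 share one core and differ in a single place, (chloro in place of methoxy on an aromatic carbon). In this assay this change produced a 1.1-fold lower number from compound 1 to compound 2 (0.06 log units; within the scatter), so the two numbers cannot be told apart. Compound 3 is built on a different core; how that core differs from the core of compound 1 is not broken down here, and all that can be said is that the values of compound 1 and compound 3 lie close together, as do those of compound 2 and compound 3.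

Compound 4, `O=C(N/N=C\c1cn(Cc2ccc(Cl)cc2)c2cc(F)ccc12)c1c[nH]c2ccc(Br)cc12`, is yet to be measured. It stands to compound 3 as compound 2 stands to compound 1: the change is chloro in place of methoxy on an aromatic carbon, and the place described for it reads the same as for the earlier pair, so this is the same change made on the second core.

The step from compound 3 to compound 4 in this assay is expected to be a 1.1-fold lower number from compound 3 to compound 4 (0.05 log units; within the scatter), set beside a 1.1-fold lower number from compound 1 to compound 2 (0.06 log units; within the scatter), because that earlier step a 1.1-fold lower number from compound 1 to compound 2 (0.06 log units; within the scatter) shows the swap leaving the number essentially unchanged. Among the compounds with values here, compound 4 is therefore estimated at 41000 nM in this assay, with a plausible range from 16000 nM to 110000 nM; the breadth of the range reflects that only one earlier instance of the change exists, and on a different core.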

Compound 4, half-maximal inhibitory concentration: 10600 nM
Estimate against measurement, compound 4: 3.9-fold (0.59 log units) above; the measured number lies below the stated range.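

On the second core, replacing 4-methoxybenzyl with 4-chlorobenzyl gave a 4.3-fold lower number from compound 3 to compound 4 (0.63 log units; beyond the scatter) in this assay, whereas on the first core the same replacement gave a 1.1-fold lower number from compound 1 to compound 2 (0.06 log units; within the scatter) and the two numbers could not be told apart. The two steps do not agree, so in this series the size of the change did not carry over from one core to the other: the same change on two cores in this assay, a 1.1-fold lower number (0.06 log units; within the scatter) from compound 1 to compound 2 and a 4.3-fold lower number (0.63 log units; beyond the scatter) from compound 3 to compound 4, 3.8-fold (0.57 log units) apart, beyond the scatter of two such steps. This shows that a step read on one of these cores was a poor guide to the step on the other, but with a single pair on each core it does not show which difference between the cores matters, nor whether either step would recur on a further core.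

The compounds shown leave open whether other groups put in place of the methoxy, such as a fluoro, a methyl, an amine or a carboxylic acid, would give a small step on the first core and a larger one on the second. They also leave open whether a core carrying the bromo without the fluoro would give the small step or the large one.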